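The source may hold more compounds than are shown below. What is called first, only, known or untested is meant among the compounds shown, and "the series" means these compounds.

Compound 3 `NC(=O)NC/C=C\CN(C[C@H]1Cc2ncccc2CN1)[C@H]1CCCc2cccnc21` gives the lowest of the three readings in an ADME assay on microsomes from liver (Rattus norvegicus) for metabolic stability, using NADPH, with a stated time of 10 min (a lower number here means that less of the compound is left, a higher number that more of the compound is left), with 1%. Compound 1 `NCCCCN(C[C@H]1Cc2cccnc2CN1)[C@H]1CCCc2cccnc21` gives 49% in this assay, and compound 2 `NCCCCN(C[C@@H]1Cc2nccnc2CN1)[C@H]1CCCc2cccnc21` gives 67%; both lie beyond the scatter above compound 3. Compound 4 `c1cnc2c(c1)CN[C@@H](CN(CCCC1CCNCC1)[C@H]1CCCc3cccnc31)C2` has not yet been measured. It differs from compound 3 by a group of 8 heavy atoms (7 carbon, 1 nitrogen; one six-membered non-aromatic ring with 1 hetero atom) in place of a group of 7 heavy atoms (4 carbon, 2 nitrogen, 1 oxygen; no ring), on a saturated chain carbon bound to an amine nitrogen. Within the data shown here, no measured pair shows this exact change, so the expected size of the step rests on the spread among the three measured compounds. Compound 4 is expected to move upward from compound 3 by a number 39 percentage points higher from compound 3 to compound 4 (beyond the scatter), beyond the scatter. The estimate for compound 4 in this assay is 40%, within a range from 10% to 75%.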

Compound 4, percent of the compound remaining: 40%
For compound 4 middle estimate and measured number coincide at the digits printed; the measured number falls inside the stated range.
By their numbers in this assay, from the lowest: compound 3; then compounds 4 and 1 (each within the scatter of the next); then compound 2.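

In this assay, replacing the open chain of compound 3 with the 2-(piperidin-4-yl)ethyl group on the same core gives a number 39 percentage points higher from compound 3 to compound 4 (beyond the scatter). Among these compounds, this shows that the group on this saturated chain carbon bound to an amine nitrogen can strongly change how much compound is left, something the earlier compounds, which differ in more than one place, could not show. Nothing measured here gives a reason for this step. As far as these compounds go, the whole group changes at once, so it stays open whether the urea, the chain double bond or the new ring accounts for the step. A piperazine ring in place of the piperidine, on the same core, would show whether the ring's atoms matter.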